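Swapping 3-methoxyphenyl for 4-hydroxyphenyl in a cytotoxic pair

A few compounds are considered here, and "the series" means these few. Any claim that something is new, unique, unknown or untested is made for them only; others in the source may bear on it.

In a functional assay on A-431 cells (Homo sapiens) for cytotoxicity (on this read-out lower numbers stand for an effect already at smaller amounts and higher numbers for an effect only at larger amounts of compound), compound 1 (`COC1=C(C)C(=O)/C(=C(O)/C=C/c2ccc(OC)cc2)C(=O)C1(C)C`) gives 9.2 ug/mL and compound 2 (`COC1=C(C)C(=O)/C(=C(O)/C=C/c2cccc(OC)c2)C(=O)C1(C)C`) gives 4.5 ug/mL as the lower of the two numbers. Compound 3 (`COC1=C(C)C(=O)/C(=C(O)/C=C/c2ccc(O)cc2)C(=O)C1(C)C`) brings 4-hydroxyphenyl in place of 3-methoxyphenyl on a double-bonded chain carbon bound to a double-bonded chain carbon and so puts 4-hydroxyphenyl in place of 3-methoxyphenyl on the double-bonded chain carbon. For the measured compounds named here, only one measured step bears on this, a 2.0-fold lower number from compound 1 to compound 2 (0.31 log units; beyond the scatter) with 3-methoxyphenyl in place of 4-methoxyphenyl, and no measured compound carries 4-hydroxyphenyl. A modest move to a higher number is therefore expected, estimated as a 1.8-fold higher number from compound 2 to compound 3 (0.25 log units; within the scatter) in size. Compound 3 is estimated at 8 ug/mL with 3 ug/mL to 22 ug/mL as its expected range.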

Compound 3, concentration for half-maximal effect: 14.9 ug/mL
Beside the measured number, compound 3's estimate is 1.9-fold (0.27 log units) below it, and the stated range covers the measured number.
By their numbers in this assay, from the lowest: compound 2; then compounds 1 and 3 (each within the scatter of the next).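

With 4-hydroxyphenyl on the double-bonded chain carbon, this assay shows a 3.3-fold higher number from compound 2 to compound 3 (0.52 log units; beyond the scatter), so the lower number of compound 2 does not carry over to this group. Hydrogen in place of methyl on the oxygen on the aromatic ring gives a 1.6-fold higher number from compound 1 to compound 3 (0.21 log units; within the scatter), leaving 4-hydroxyphenyl and 4-methoxyphenyl unseparated here while compound 2, with 3-methoxyphenyl, stands apart from both. Nothing available explains this difference. Open remains whether 3-hydroxyphenyl would match compound 2, and how an aminophenyl or a carboxylic acid on the ring would read.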